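Methyl in place of fluoro: compound 3 to compound 4

A few compounds are considered here, and "the series" means these few. Any claim that something is new, unique, unknown or untested is made for them only; others in the source may bear on it.

Measured compounds in an ADME assay on the whole organism with Oryza sativa as the target, tested at 10 uM; a lower number here means a stronger effect, a higher number a weaker effect of the compound at the concentration tested:
compound 1, `Cc1ccccc1NC(=O)N[C@@H](C)c1ccccc1`, gives 99%
compound 2, `C[C@@H](NC(=O)Nc1ccc(F)cc1F)c1ccccc1`, gives 93%
compound 3, `C[C@H](NC(=O)Nc1ccc(F)cc1F)c1ccccc1`, gives 99%

Compound 3 stands level with compound 1 at the digits shown, the two together the highest of the three numbers in this assay; compound 2 is the furthest from it, and the step of a number 6 percentage points higher from compound 2 to compound 3 (within the scatter) lies within the scatter. That step rests on configuration alone, as the fact that compounds 2 and 3 differ only in the configuration as drawn shows, so it says little about a group exchange. The change to compound 4, `Cc1cc(F)ccc1NC(=O)N[C@@H](C)c1ccccc1`, is methyl in place of fluoro on an aromatic carbon. No measured step exchanges these two groups, but compound 1, which carries the methyl, and compound 3 give the same number at the digits shown. Compound 4 is therefore expected to sit with them, with a step of a number 1 percentage points lower from compound 3 to compound 4 (within the scatter) not beyond the scatter. For compound 4 the estimated value is 98%, with a range from 90% to 100%.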

Compound 4, a percentage reported as activity, at one concentration (the size of the read-out at that concentration, not a potency): 96%
For compound 4 the middle estimate is 2 percentage points above the measured one; measured number inside the range.
By their numbers in this assay, from the lowest: compounds 2, 4, 1 and 3 (each within the scatter of the next).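

In this assay, within the data shown here, methyl in place of fluoro on an aromatic carbon ortho to a large group gives a number 3 percentage points lower from compound 3 to compound 4 (within the scatter) in the first direct exchange of these two groups. Fluoro in place of hydrogen on an aromatic carbon gives a number 3 percentage points lower from compound 1 to compound 4 (within the scatter) so neither change moves the number beyond the scatter. Nothing measured here accounts for these numbers.

On these data alone, whether an amine, a methoxy group or a carboxylic acid on this carbon would give a step beyond the scatter stays open. So does whether methyl in place of fluoro reads the same with the stereocentre drawn R.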